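The source may hold more compounds than are shown below. What is called first, only, known or untested is meant among the compounds shown, and "the series" means these compounds.

- compound 1, `CN(C)CCNc1cc2c(cn1)cc(NC(=O)c1ccc(N)cc1)c(=O)n2C`: 55800 nM
- compound 2, `CN(C)CCNc1cc2c(cn1)cc(NC(=O)/C=C/c1ccccc1)c(=O)n2C`: 27400 nM

In a functional assay on MCF7 cells (Homo sapiens) for antiproliferative activity, read by MTT assay, with a stated time of 48 h (a higher number here means a weaker inhibitor, a lower number a stronger inhibitor), compound 2 holds the lower of the two numbers, at 27400 nM. Compound 3, `COc1ccc(C(=O)Nc2cc3cnc(NCCN(C)C)cc3n(C)c2=O)cc1`, is still unmeasured and differs from it thus: 4-methoxyphenyl in place of 2-phenylethenyl on a carbonyl carbon. Going by the values given here, only one measured step bears on this change, the modest 2.0-fold lower number from compound 1 to compound 2 (0.31 log units; beyond the scatter), which exchanged 4-aminophenyl for 2-phenylethenyl at the same place. Compound 3 again carries a substituted phenyl there, as compound 1 does, so a modest move back towards a higher number is expected. The expected change is a 1.5-fold higher number from compound 2 to compound 3 (0.16 log units; within the scatter). Compound 3 is estimated at 40000 nM, with an expected range of 15000 nM to 90000 nM.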

Compound 3, half-maximal inhibitory concentration: 37300 nM
Beside the measured number, compound 3's estimate is 1.1-fold (0.03 log units) above it; low and high end bracket the measured number.
By their numbers in this assay, from the lowest: compounds 2, 3 and 1 (each within the scatter of the next, the first and the last beyond it).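

In this assay, 4-methoxyphenyl in place of 2-phenylethenyl on a carbonyl carbon gives a 1.4-fold higher number from compound 2 to compound 3 (0.13 log units; within the scatter), so the substituted phenyl and the 2-phenylethenyl group cannot be told apart here in this pair. Methoxy in place of amino on an aromatic carbon gives a 1.5-fold lower number from compound 1 to compound 3 (0.17 log units; within the scatter), so compound 3 sits within the scatter of both neighbours, although compound 1 and compound 2 lie beyond the scatter of each other. Nothing available accounts for these numbers.

On these data alone, it remains open whether a carboxylic acid or a longer saturated chain on this carbonyl carbon would move the number beyond the scatter of these three compounds.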